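Methylamino for piperidin-1-yl on the carbonyl carbon

A few compounds are considered here, and "the series" means these few. Any claim that something is new, unique, unknown or untested is made for them only; others in the source may bear on it.

Compound 1 `N#Cc1ccc(NCc2cncn2Cc2ccc(-c3ccccc3)cc2)cc1-c1ccccc1` reads > 1000 nM in a toxicity assay on NIH3T3 cells (Mus musculus) for cytotoxicity, read by resazurin assay (a lower number here means that less compound is needed, a higher number that more compound is needed for the effect), which is a limit of the assay and not a number. Compound 2 `O=C(c1ccc(NCc2cncn2Cc2ccc(-c3ccccc3)cc2)cc1-c1ccccc1)N1CCCCC1` reads > 1000 nM in this assay, also a limit, so its position is bounded on one side only. Compound 3 `CNC(=O)c1ccc(NCc2cncn2Cc2ccc(-c3ccccc3)cc2)cc1-c1ccccc1` carries methylamino in place of piperidin-1-yl on a carbonyl carbon. Among the measured compounds shown here, the one measured step with a bearing on this change is a step that the two limits leave unreadable from compound 1 to compound 2, and it has no readable size. The evidence so far is the limit of > 1000 nM in this assay, at which 2 of the 2 values shown sit. On that basis, no step beyond the scatter is expected in this assay, and another limit is the likeliest reading. The estimated step is a step that the limit leaves unreadable from compound 2 to compound 3. For compound 3 the expected value is 3000 nM, with an estimated range from 1000 nM to 10000 nM.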

Compound 3, half-maximal effective concentration: > 1000 nM
Compound 3 was reported as a limit (the forecaster's own chance of this, stated with the estimate: 85%); the middle value is on the limit's open side.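

Compound 1, compound 2 and compound 3 all stand at a limit of the assay in this assay, so no step among them can be read: the limit of > 1000 nM in this assay, at which 3 of the 3 values shown sit.

The compounds shown leave open whether cyano, (piperidin-1-yl)carbonyl and methylcarbamoyl differ at all in this read-out, and at what concentration any of the three compounds would give the effect.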